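The source may hold more compounds than are shown below. What is called first, only, known or untested is meant among the compounds shown, and "the series" means these compounds.

Measured in a functional assay on A549 cells (Homo sapiens) for antiproliferative activity, read by MTT assay, with a stated time of 72 h; on this read-out higher numbers stand for weaker inhibition and lower numbers for stronger inhibition:
- compound 1 `COc1cc(-n2ncnc2-c2ccc(C)cc2)cc(OC)c1OC`: 1100 nM
- compound 2 `COc1ccc(-c2ncnn2-c2cc(OC)c(OC)c(OC)c2)cc1`: 520 nM
- compound 3 `COc1cc(-n2ncnc2-c2ccc(Cl)cc2)cc(OC)c1OC`: > 10000 nM, a limit of the assay and not a number

Compound 3 therefore has no exact place on the scale and stands at the limit of > 10000 nM in this assay, at which 1 of the 3 values shown sits. Compound 4 `COc1cccc(-c2ncnn2-c2cc(OC)c(OC)c(OC)c2)c1` has not yet been measured. It carries 3-methoxyphenyl in place of the 4-chlorophenyl of compound 3, on an aromatic carbon of a five-membered aromatic ring with 3 nitrogen: 3-methoxyphenyl in place of 4-chlorophenyl on an aromatic carbon.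

Two measured steps show what chloro has cost in this series. Chloro in place of methoxy gave an at least 19-fold higher number from compound 2 to compound 3 (1.28 log units; beyond the scatter), and chloro in place of methyl gave an at least 9.0-fold higher number from compound 1 to compound 3 (0.95 log units; beyond the scatter). Methoxy in place of methyl gave a 2.1-fold lower number from compound 1 to compound 2 (0.33 log units; beyond the scatter), a modest gain. Leaving the chloro group behind should therefore lower the number, probably by a modest to large step. However, no measured compound carries the 3-methoxyphenyl group, so the size remains uncertain, and a result at the limit cannot be ruled out.

The estimated change is an at least 4.0-fold lower number from compound 3 to compound 4 (0.60 log units; beyond the scatter). For compound 4 the expected value is 2500 nM, with an estimated range from 400 nM to 10000 nM.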

Compound 4, half-maximal inhibitory concentration: > 10000 nM
Compound 4 ended at the assay's limit (the forecaster's own chance of this, stated with the estimate: 30%); middle value at least 4.0-fold (0.60 log units) from the limit.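

Replacing 4-methoxyphenyl with 3-methoxyphenyl in this assay gave an at least 19-fold higher number from compound 2 to compound 4 (1.28 log units; beyond the scatter), so among these compounds the presence of a methoxy group does not by itself give the lower number: compound 2 and compound 4 differ only in how that group is placed on the phenyl ring. The step to 3-methoxyphenyl from 4-methylphenyl gave an at least 9.0-fold higher number from compound 1 to compound 4 (0.95 log units; beyond the scatter), which shows that removing the chloro group of compound 3 does not by itself restore the activity of compound 1 or compound 2. The step between compound 3 and compound 4 cannot be read, as compound 4, like compound 3, has only a limit and not a number: the limit of > 10000 nM in this assay, at which 2 of the 4 values shown sit.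

On these data alone, how far compound 3 and compound 4 lie beyond that limit remains unknown, so these two groups cannot be ranked against each other. As far as these compounds go, it also remains open whether the low numbers extend to other groups at this place, such as 4-ethoxyphenyl or 4-aminophenyl, and whether 3-methylphenyl would follow 3-methoxyphenyl to the limit.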